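Swapping nitro for fluoro on two compounds at the limit

The compounds below may be only part of what the source reports. "The series", "measured", "known", "first", "only" and "open" are said of these compounds alone.

compound 1 `Nn1c(SCc2ccccc2)nnc1-c1c[nH]c2ccccc12`: > 100000 nM
compound 2 `Nn1c(SCc2ccc([N+](=O)[O-])cc2)nnc1-c1c[nH]c2ccccc12`: > 100000 nM

In a functional assay on Jurkat cells (Homo sapiens) for cytotoxicity, with a stated time of 24 h (on this read-out higher numbers stand for weaker inhibition and lower numbers for stronger inhibition), compound 1 gives > 100000 nM, which is a limit of the assay and not a number. In this assay compound 2 gives > 100000 nM, again a limit. The step that the two limits leave unreadable from compound 1 to compound 2 therefore cannot be read in size or direction. Compound 2 thus stands only at the limit of > 100000 nM in this assay, at which 2 of the 2 values shown sit, with no number of its own.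

Compound 3 `Nn1c(SCc2ccc(F)cc2)nnc1-c1c[nH]c2ccccc12` differs from compound 2 by fluoro in place of nitro on an aromatic carbon. For the measured compounds named here, the only measured step, a step that the two limits leave unreadable from compound 1 to compound 2, concerns the same position of the ring and bears on this change, yet it leaves no readable size, so no step beyond the scatter can be expected in this assay. Compound 3 is expected to give 150000 nM, within a range from 30000 nM to 1000000 nM. This estimate means an expected step that the limit leaves unreadable from compound 2 to compound 3, most likely reported once more only as a limit.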

Compound 3, half-maximal inhibitory concentration: > 100000 nM
Compound 3 gave a limit, no number; the forecaster's own chance of this, stated with the estimate: 75%; the middle value is on the limit's open side.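

In this assay compound 3 gives > 100000 nM, which is a limit of the assay and not a number. For the compounds shown here, no step among compound 1, compound 2 and compound 3 can therefore be read. Whether hydrogen, nitro or fluoro on the ring makes any difference stays open, because all three compounds share one result: the limit of > 100000 nM in this assay, at which 3 of the 3 values shown sit.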